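This account rests on a few compounds, and the source may have more. Where it says the series, first, only, none or still open, it means among the compounds named here.

In a functional assay on PC-3 cells (Homo sapiens) for antiproliferative activity, read by MTT assay, with a stated time of 72 h (on this read-out lower numbers stand for stronger inhibition and higher numbers for weaker inhibition), two compounds with the same core have been measured so far. Compound 1 `CCNC(=S)SCC1=CCOC1=O` gives 30600 nM, the lower of the two numbers, and compound 2 `O=C1OCC=C1CSC(=S)NC1CC1` gives 117000 nM. The next compound to consider is compound 3 `O=C1OCC=C1CSC(=S)NCc1ccccc1`, which differs from compound 1 in one place: phenyl in place of methyl on a saturated chain carbon bound to an amide-type nitrogen. Among the measured compounds shown here, only one measured step bears on this change, and only indirectly. In a 3.8-fold higher number from compound 1 to compound 2 (0.58 log units; beyond the scatter), a modest step beyond the usual scatter, cyclopropyl replaces ethyl on an amide-type nitrogen. That step shows that the number can move when the group on this nitrogen changes, but it is a different swap and gives no clear direction for adding phenyl. The expectation is therefore a small step, not beyond the scatter, with a wide margin on either side. The expected step is a 1.3-fold higher number from compound 1 to compound 3 (0.12 log units; within the scatter). For compound 3 the estimated value is 40000 nM, with an expected range from 12000 nM to 130000 nM.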

Compound 3, half-maximal inhibitory concentration: 13700 nM
Compound 3: middle estimate off by 2.9-fold (0.47 log units), on the high side; low and high end bracket the measured number.
By their numbers in this assay, from the lowest: compound 3; then compound 1; then compound 2.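

In this assay, among the compounds shown here, phenyl in place of methyl on a saturated chain carbon bound to an amide-type nitrogen gives a 2.2-fold lower number from compound 1 to compound 3 (0.35 log units; beyond the scatter), the first change here that lowers the number instead of raising it. Set against a 3.8-fold higher number from compound 1 to compound 2 (0.58 log units; beyond the scatter), where cyclopropyl replaces ethyl on the nitrogen, this shows that changing the group on this nitrogen can move the number in either direction. It also shows that a group as large as one with a six-membered aromatic ring can sit at this place without the number rising, although the step is modest and rests on a single pair of compounds.

Still open, going by these compounds, is whether the lower number depends on the aromatic ring itself, which a cyclohexyl group in place of the phenyl would help to separate, and whether a longer chain between the nitrogen and the phenyl, such as a phenylethyl group, would lower the number further. Nothing measured here explains why the number falls with phenyl and rises with cyclopropyl.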